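From Difluoromethoxy to Chloro on Compound 1

A few compounds are considered here, and "the series" means these few. Any claim that something is new, unique, unknown or untested is made for them only; others in the source may bear on it.

In an in vitro ADME assay on microsomes (Homo sapiens) for metabolic stability (on this read-out higher numbers stand for a longer-lived compound and lower numbers for a shorter-lived compound), compound 1 (`CCc1nc(NC(CC)CC)c(OC)nc1-c1ccc(OC(F)F)cc1Cl`) gives 2 h, the higher of the two numbers available and beyond the scatter from the other one. There, compound 2 (`CCc1nc(-c2ccc(OC(F)(F)F)cc2OC)c(OC)nc1NC(CC)CC`) gives 0.867 h. Compound 3 (`CCc1nc(NC(CC)CC)c(OC)nc1-c1ccc(Cl)cc1Cl`) keeps the core of compound 1 but has chloro in place of difluoromethoxy on an aromatic carbon. Among the measured compounds shown here, no measured pair shows this change, so only a small downward shift, within the scatter, is expected. The estimated step is a 1.3-fold lower number from compound 1 to compound 3 (0.10 log units; within the scatter). Compound 3 is expected at 1.6 h, with an estimated range from 0.7 h to 3.5 h.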

Compound 3, half-life: 0.583 h
For compound 3 the middle estimate is 2.7-fold (0.44 log units) above the measured one, and the stated range ends above it.
By their numbers in this assay, from the lowest: compounds 3 and 2 (each within the scatter of the next); then compound 1.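

This pair shows that the position is sensitive to the change: in this assay, chloro in place of difluoromethoxy on the aromatic carbon meta to a chloro group gives a 3.4-fold lower number from compound 1 to compound 3 (0.54 log units; beyond the scatter) and the step lies beyond the scatter. On the core of compound 1, the difluoromethoxy compound is therefore the longer-lived of the two. Nothing available explains this difference, and this single pair cannot tie it to any feature of either group.

From the compounds shown here alone, it remains open whether the shift holds on other cores. Also open, going by these compounds, is where a fluoro group or a nitrile would fall at this position.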